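Swapping Methyl for Isopropyl in a Two-Compound Series

A few compounds are considered here, and "the series" means these few. Any claim that something is new, unique, unknown or untested is made for them only; others in the source may bear on it.

- compound 1 `Nc1ccccc1NC(=O)c1ccc(COc2ccc(Cl)cc2)cc1` gives 17300 nM
- compound 2 `Cc1ccc(OCc2ccc(C(=O)Nc3ccccc3N)cc2)cc1` gives 4860 nM

Going by the values given here, in a functional assay on HCT-116 cells (Homo sapiens) for antiproliferative activity, read by CCK-8 assay, with a stated time of 72 h (a higher number here means a weaker inhibitor, a lower number a stronger inhibitor), compound 2 gives 4860 nM, the lowest number so far, while compound 1 stands higher at 17300 nM. The next compound is compound 3 `CC(C)c1ccc(OCc2ccc(C(=O)Nc3ccccc3N)cc2)cc1`, which keeps the core of compound 2 and carries isopropyl in place of methyl on an aromatic carbon. That change counts as isopropyl in place of methyl on an aromatic carbon and is the only difference between them.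

Among the compounds with values here, one measured step bears on it, the modest 3.6-fold lower number from compound 1 to compound 2 (0.55 log units; beyond the scatter) at the same place. Within the data shown here, that step replaced chloro with methyl, so it gives no direct reading of isopropyl, and no measured compound carries that group. With so little to go on, no step beyond the scatter is expected in this assay, with only a slight lean towards a lower number. The estimate means an expected 1.2-fold lower number from compound 2 to compound 3 (0.08 log units; within the scatter) and nothing larger. For compound 3 the estimated value is 4000 nM, with an expected range from 1500 nM to 11000 nM at its two ends.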

Compound 3, half-maximal inhibitory concentration: 4570 nM
Compound 3: middle estimate off by 1.1-fold (0.06 log units), on the low side; the range from low to high includes it.
By their numbers in this assay, from the lowest: compounds 3 and 2 (each within the scatter of the next); then compound 1.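

In this assay, replacing methyl with isopropyl on the aromatic carbon para to a large group gives a 1.1-fold lower number from compound 2 to compound 3 (0.03 log units; within the scatter), so compound 2 and compound 3 stand level within the scatter although the group grows from one heavy atom to three. Measured against the chloro compound, isopropyl gives a 3.8-fold lower number from compound 1 to compound 3 (0.58 log units; beyond the scatter), a step of much the same size as the one methyl gave, so both carbon groups now sit on the same side of compound 1 and the gap to it no longer rests on methyl alone. No measurement shown here accounts for either the level pair or the gap to the chloro compound.

On these data alone, what a methoxy group, an amine or a carboxylic acid would do at this place stays open, as does whether tert-butyl or a longer chain would stay level with compound 2 and compound 3. As far as these compounds go, it is also open whether the higher number of compound 1 belongs to chloro in particular or would be shared by fluoro or bromo at the same carbon.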